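Swapping the solubilising side chain on the core of compound 1

The source may report more compounds than this note shows. Statements on the series, on what has been measured and on what is new or still open speak of the compounds shown alone.

Three measured compounds share one core and differ in the group carried on the aromatic nitrogen. Compound 1 `C=CC(=O)Nc1cc(Nc2ncc3ncn(-c4ccc(C(C)C)cc4)c3n2)c(OC)cc1N(C)CCN(C)C` gives 15300 nM in an ADME assay on HT-29 cells (Homo sapiens) for cytotoxicity, read by MTT assay, with a stated time of 72 h; on this read-out higher numbers stand for weaker inhibition and lower numbers for stronger inhibition. Compound 2 `C=CC(=O)Nc1cc(Nc2ncc3ncn(-c4ccc(F)cc4)c3n2)c(OC)cc1N(C)CCN(C)C` gives 12000 nM, and compound 3 `C=CC(=O)Nc1cc(Nc2ncc3ncn(C4CCCC4)c3n2)c(OC)cc1N(C)CCN(C)C` gives 20900 nM. Compound 1 thus sits second highest of the three numbers, and the steps of a 1.3-fold lower number from compound 1 to compound 2 (0.11 log units; within the scatter), a 1.4-fold higher number from compound 1 to compound 3 (0.14 log units; within the scatter) and a 1.7-fold higher number from compound 2 to compound 3 (0.24 log units; within the scatter) all stay within the scatter, so the three compounds cannot be ranked.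

Compound 4 `C=CC(=O)Nc1cc(Nc2ncc3ncn(-c4ccc(C(C)C)cc4)c3n2)c(OC)cc1N1CCN(C)CC1` changes a different place: 4-methylpiperazin-1-yl in place of (2-(dimethylamino)ethyl)(methyl)amino on an aromatic carbon. Among the measured compounds shown here, none of the measured steps touches this position, so no measured step bears directly on the change. What the measured compounds do show is that altering a peripheral group on this core left the read-out essentially unchanged. On that basis a step from compound 1 to compound 4 of no more than the scatter, in either direction, is expected, namely a 1.0-fold lower number from compound 1 to compound 4 (0.01 log units; within the scatter). The estimated value for compound 4 is 15000 nM, with a range from 6000 nM to 40000 nM.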

Compound 4, half-maximal inhibitory concentration: 7690 nM
Estimate against measurement, compound 4: 2.0-fold (0.29 log units) above; the range from low to high includes it.
By their numbers in this assay, from the lowest: compounds 4, 2, 1 and 3 (each within the scatter of the next, the first and the last beyond it).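

In this assay, replacing the open (2-(dimethylamino)ethyl)(methyl)amino chain with the ring of 4-methylpiperazin-1-yl gives a 2.0-fold lower number from compound 1 to compound 4 (0.30 log units; within the scatter) and so cannot be told apart from no change. Among the compounds shown here, this is the first measured change at this place on the shared core, and the two groups have the same counts of heavy atoms, hydrogen-bond donors and acceptors, so the swap mainly tests an open chain against a ring. No measured property of either group is available to account for this result.

Going by these compounds, it remains open whether a morpholine ring or a longer chain such as (3-(dimethylamino)propyl)(methyl)amino would give a clearer step here. On these data alone, it is also open whether 4-methylpiperazin-1-yl would give a similar result with 4-fluorophenyl or cyclopentyl on the aromatic nitrogen.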